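A few compounds are considered here, and "the series" means these few. Any claim that something is new, unique, unknown or untested is made for them only; others in the source may bear on it.

Working notes on the series. Going by the values given here, in a functional assay on MDA-MB-453 cells (Homo sapiens) for antiproliferative activity (on this read-out lower numbers stand for stronger inhibition and higher numbers for weaker inhibition), compound 1 `COc1cc(N(CCCSC(=S)N2CCN(C(C)=O)CC2)S(=O)(=O)c2cccc3cccnc23)cc(OC)c1OC` gives 700 nM and compound 2 `COc1cc(N(CCCSC(=S)N2CCN(C)CC2)S(=O)(=O)c2cccc3cccnc23)cc(OC)c1OC` gives 700 nM, so compound 2 stands level with compound 1, its only measured neighbour. Compound 3 `CCN1CCN(C(=S)SCCCN(c2cc(OC)c(OC)c(OC)c2)S(=O)(=O)c2cccc3cccnc23)CC1` has not yet been measured. Its difference from compound 2 is methyl in place of hydrogen on a saturated chain carbon bound to an amine nitrogen in a ring, which reads as 4-methylpiperazin-1-yl to 4-ethylpiperazin-1-yl. Among the compounds with values here, one measured step bears on this change: no change at the digits printed from compound 1 to compound 2 (within the scatter), with methyl in place of acetyl on an amine nitrogen in a ring. That single step stayed within the scatter, so no step beyond the scatter is expected in this assay, and neither direction is favoured. The expected step is no change at the digits printed from compound 2 to compound 3 (within the scatter). The estimate for compound 3 is 700 nM, with an expected range of 300 nM to 1500 nM.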

Compound 3, half-maximal inhibitory concentration: 700 nM
The estimate for compound 3 equals the measured number at the digits printed; measured number inside the range.
By their numbers in this assay, from the lowest: compounds 1, 2 and 3 (each within the scatter of the next).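

In this assay, the exchange of 4-methylpiperazin-1-yl for 4-ethylpiperazin-1-yl gives no change at the digits printed from compound 2 to compound 3 (within the scatter), so a methyl in place of hydrogen on a saturated chain carbon bound to an amine nitrogen in a ring leaves the read-out where it was. The ethyl in place of acetyl gives no change at the digits printed from compound 1 to compound 3 (within the scatter), which extends the earlier acetyl and methyl pair to three groups on this ring nitrogen that cannot be told apart in this read-out. Nothing available explains this sameness.

Still open, on these data alone, is whether a free amine hydrogen, a longer chain such as butyl, a benzyl group or a chain ending in a carboxylic acid on this ring nitrogen would stay at this level. The compounds shown also leave open whether the same holds in any other assay.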